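The compounds below may be only part of what the source reports. "The series", "measured", "known", "first", "only" and "open" are said of these compounds alone.

Compound 1 `COc1ccc(CCCN2CCC(COCc3ccccc3)CC2)cc1` gives 2100 nM.
Compound 2 `COc1cccc(CCCN2CCC(COC(c3ccccc3)c3ccccc3)CC2)c1` gives 1500 nM.

In a functional assay on cells (T-cell line, Homo sapiens) for inhibition (on this read-out higher numbers stand for weaker inhibition and lower numbers for stronger inhibition), compound 2 holds the lowest of the two numbers, and its nearest neighbour is compound 1; the gap between them lies within the scatter, so no order is claimed. Compound 3 `CCCCCCCCCN1CCC(COC(c2ccccc2)c2ccccc2)CC1` has not yet been measured. It differs from compound 2 by hexyl in place of 3-methoxyphenyl on a saturated chain carbon, three bonds along the chain from an amine nitrogen in a ring. Among the measured compounds shown here, no step between measured compounds bears on this change, so only a modest step in this assay, toward a higher number, is expected. Compound 3 is estimated at 3000 nM, within 800 nM to 12000 nM, which means an expected step of a 2.0-fold higher number from compound 2 to compound 3 (0.30 log units; within the scatter).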

Compound 3, half-maximal inhibitory concentration: 700 nM
The estimate for compound 3 lay 4.3-fold (0.63 log units) above the measured number, outside the stated range (below it).
By their numbers in this assay, from the lowest: compound 3; then compounds 2 and 1 (each within the scatter of the next).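

In this assay, among the compounds shown here, the exchange of 3-methoxyphenyl for hexyl, on a saturated chain carbon, three bonds along the chain from an amine nitrogen in a ring, gives a 2.1-fold lower number from compound 2 to compound 3 (0.33 log units; beyond the scatter) and is the first step here beyond the scatter. With the shared core kept, this position therefore takes an open chain without any aromatic ring and without losing inhibition. Nothing shown accounts for this step.

Going by these compounds, whether a shorter or longer chain would continue this step remains open. So does the effect of a hydroxyl, an amine or a carboxylic acid at the end of the chain.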